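Swapping a phenyl for a dimethoxyphenyl on the ketone

This account rests on a few compounds, and the source may have more. Where it says the series, first, only, none or still open, it means among the compounds named here.

Of the compounds shown here, two have numbers so far. Compound 1 `COc1ccc(C(=O)/C=C/c2cn(-c3ccccc3)nc2-c2ccsc2)cc1OC` gives 1600 nM in a functional assay on HCT-116 cells (Homo sapiens) for inhibition, read by sulforhodamine B assay, with a stated time of 72 h; a lower number here means a stronger inhibitor, a higher number a weaker inhibitor. Compound 2 `O=C(/C=C/c1cn(-c2ccccc2)nc1-c1cccnc1)c1ccccc1` gives 2000 nM in this assay, the higher of the two numbers, though its gap to compound 1 falls within the usual scatter of repeated measurements, so the two cannot be ranked. Within the data shown here, compound 1 and compound 2 differ in more than one place, so no single step between them can be read off.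

Compound 3 `COc1ccc(C(=O)/C=C/c2cn(-c3ccccc3)nc2-c2cccnc2)cc1OC` has not yet been measured. It is derived from compound 2 by one change: 3,4-dimethoxyphenyl in place of phenyl on a carbonyl carbon. Compound 1 already carries the same 3,4-dimethoxyphenyl on its carbonyl carbon. Its other parts differ from compound 2, however, and so it gives no clean guide to the size of this step. On the two values in hand, the change is expected to shift the number little, if at all, and most likely not beyond the scatter, with compound 3 expected at 1500 nM in this assay, in the range 500 nM to 4500 nM. The expected step is a 1.3-fold lower number from compound 2 to compound 3 (0.12 log units; within the scatter).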

Compound 3, half-maximal inhibitory concentration: 4300 nM
For compound 3 the middle estimate is 2.9-fold (0.46 log units) below the measured one; the range from low to high includes it.
By their numbers in this assay, from the lowest: compounds 1 and 2 (each within the scatter of the next); then compound 3.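

Among these compounds, putting 3,4-dimethoxyphenyl in place of phenyl on the carbonyl carbon gives, in this assay, a 2.2-fold higher number from compound 2 to compound 3 (0.33 log units; beyond the scatter), the first step at this position that can be read cleanly, and it shows that the position responds to this change, though only modestly, and that the added methoxy groups bring no gain here. The second step concerns a different place on the shared core: pyridin-3-yl in place of thiophen-3-yl on an aromatic carbon gives a 2.7-fold higher number from compound 1 to compound 3 (0.43 log units; beyond the scatter), so with 3,4-dimethoxyphenyl on the carbonyl carbon, the thiophen-3-yl compound has the lower number of the pair. Nothing in the data shown explains why either step goes the way it does.

Going by these compounds, whether the step on the carbonyl carbon would keep its size and direction with thiophen-3-yl in place of pyridin-3-yl stays open. On these data alone, the two methoxy groups also enter together, so how much each contributes is unknown, and it remains to be seen how a single methoxy or an amine on that ring would read.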